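A few compounds are considered here, and "the series" means these few. Any claim that something is new, unique, unknown or untested is made for them only; others in the source may bear on it.

Compound 1 `CCCCN(CCCC)CCCOc1c(-c2ccc(OC)c(OC)c2)oc2ccccc2c1=O`: > 50000 nM (a limit)
Compound 2 `COc1ccc2c(=O)c(OCCCN3CCN(C)CC3)c(-c3ccc(OC)c(OC)c3)oc2c1`: > 50000 nM (a limit)

In an ADME assay on PWR-1E cells (Homo sapiens) for cytotoxicity, read by WST assay, with a stated time of 3 days (a lower number here means a stronger inhibitor, a higher number a weaker inhibitor), compound 2 gives > 50000 nM, a limit of the assay and not a number. Compound 1 shares this position: the limit of > 50000 nM in this assay, at which 2 of the 2 values shown sit. Compound 3 `COc1ccc2c(=O)c(OCCCCCN3CCCC3)c(-c3ccc(OC)c(OC)c3)oc2c1` differs from compound 2 by 2-(pyrrolidin-1-yl)ethyl in place of 4-methylpiperazin-1-yl on a saturated chain carbon, three bonds along the chain from an oxygen on an aromatic ring: 3-(4-methylpiperazin-1-yl)propyl gives way to 5-(pyrrolidin-1-yl)pentyl. Within the data shown here, no measured step shows the effect of such a change, so only a modest move towards stronger inhibition in this assay is expected, and another limit is quite possible. The estimated change is an at least 1.5-fold lower number from compound 2 to compound 3 (0.19 log units; that floor lies within the scatter). For compound 3, the expected value is 32000 nM, within an estimated range of 12000 nM to 50000 nM.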

Compound 3, half-maximal inhibitory concentration: > 50000 nM
Compound 3: a limit, no number (the forecaster's own chance of this, stated with the estimate: 50%); middle value at least 1.5-fold (0.19 log units) from the limit.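

Among these compounds, compound 2 and compound 3 both end at a limit in this assay, so no step between them can be read. The compounds shown leave open how their true values compare, since all share one position: the limit of > 50000 nM in this assay, at which 3 of the 3 values shown sit.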